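Notes on an arylmethyl series: carbamate replacing the imidazoline

A few compounds are considered here, and "the series" means these few. Any claim that something is new, unique, unknown or untested is made for them only; others in the source may bear on it.

Measured so far:
compound 1 `Cc1nc2c(OCc3ccccc3)cccn2c1CO` — 99%
compound 2 `Cc1nc2c(OCc3ccccc3)cccn2c1CC1=NCCN1` — 69%

In a functional assay on the whole organism with Rattus norvegicus as the target, with a stated time of 4 h, at a dose of 40 mg/kg by the intraperitoneal route (a higher number here means more inhibition at the dose given (going by the name of the read-out), a lower number less inhibition), compound 1 gives 99%, and compound 2 gives 69%. Among the measured compounds shown here, compound 2 is the lowest of the two numbers, and the step of a number 30 percentage points lower from compound 1 to compound 2 (beyond the scatter) lies beyond the scatter, so the one change measured so far at this carbon moved the read-out by a modest amount.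

Compound 3 `Cc1nc2c(OCc3ccccc3)cccn2c1COC(=O)N(C)C` is not yet measured. Its change from compound 2 is a group of 6 heavy atoms (3 carbon, 1 nitrogen, 2 oxygen; no ring) in place of a group of 5 heavy atoms (3 carbon, 2 nitrogen; one five-membered non-aromatic ring with 2 hetero atoms), on a saturated chain carbon bound to an aromatic carbon. For the measured compounds named here, the only measured step that bears on it is a number 30 percentage points lower from compound 1 to compound 2 (beyond the scatter), which was made at the same place and points the other way from the change now considered: compound 3 again carries oxygen on this carbon, as compound 1 does, though with a larger group attached. Going by the values given here, no measured pair shows exactly this exchange, so the size is uncertain. An upward step from compound 2 is expected, most likely of a size comparable to the earlier one, giving a number 16 percentage points higher from compound 2 to compound 3 (beyond the scatter).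

For compound 3 the estimate in this assay is 85%, with a range from 55% to 99%.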

Compound 3, a percentage reported as inhibition, in the whole organism at one dose (the size of the read-out at that dose, not a potency): 75%
Beside the measured number, compound 3's estimate is 10 percentage points above it; the range from low to high includes it.
By their numbers in this assay, from the lowest: compounds 2 and 3 (each within the scatter of the next); then compound 1.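

In this assay, putting (dimethylcarbamoyl)oxy in place of the five-membered non-aromatic ring group, on a saturated chain carbon bound to an aromatic carbon, gives a number 6 percentage points higher from compound 2 to compound 3 (within the scatter), so the two groups cannot be told apart at this place even though the entering group has no ring. Dimethylcarbamoyl in place of hydrogen on the oxygen of compound 1 gives a number 24 percentage points lower from compound 1 to compound 3 (beyond the scatter), which shows that keeping oxygen on this carbon does not by itself hold the read-out, and both changes made from compound 1 lower the number beyond the scatter. No measurement at hand bears on why either step takes the size it does.

The compounds shown leave open whether a methyl ether or an acetyl ester on that oxygen would stay with compound 1 or fall with compound 3, and whether an amine on the same carbon would do the same as the groups in compound 2 and compound 3. On these data alone, the read-out gives the size of the effect at one dose and not a potency, so how compound 2 and compound 3 compare at other doses also stays open.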